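Extending the alkyl on the aromatic nitrogen

This account rests on a few compounds, and the source may have more. Where it says the series, first, only, none or still open, it means among the compounds named here.

In an assay on Prostate gland for inhibition of steroid 5-alpha-reductase (Rattus norvegicus) (on this read-out higher numbers stand for weaker inhibition and lower numbers for stronger inhibition), compound 1 `C/C(=C\C(=O)Nc1ccccc1OCCCC(=O)O)c1ccc2c(ccn2C)c1` gives 780 nM. In the same assay compound 2 `CCC(C)n1ccc2cc(/C(C)=C/C(=O)Nc3ccccc3OCCCC(=O)O)ccc21` gives 67 nM, the lowest of the two numbers measured, as the step of a 12-fold lower number from compound 1 to compound 2 (1.07 log units; beyond the scatter) shows. Compound 3 `CCCC(C)n1ccc2cc(/C(C)=C/C(=O)Nc3ccccc3OCCCC(=O)O)ccc21` differs from compound 2 by methyl in place of hydrogen on a saturated chain carbon, three bonds along the chain from an aromatic nitrogen, sec-butyl becoming 1-methylbutyl. For the measured compounds named here, the only measured step that bears on this, a 12-fold lower number from compound 1 to compound 2 (1.07 log units; beyond the scatter), was large but involved a bigger change than the present one. A smaller step in the same direction, or none beyond the scatter, is therefore expected in this assay. Compound 3 is estimated at 45 nM, with a range from 15 nM to 150 nM, which means an expected 1.5-fold lower number from compound 2 to compound 3 (0.17 log units; within the scatter).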

Compound 3, half-maximal inhibitory concentration: 7.8 nM
The estimate for compound 3 lay 5.8-fold (0.76 log units) above the measured number; measured number below the stated range.
By their numbers in this assay, from the lowest: compound 3; then compound 2; then compound 1.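

A single methyl on a saturated chain carbon, three bonds along the chain from an aromatic nitrogen, still counts in this assay with an 8.6-fold lower number from compound 2 to compound 3 (0.93 log units; beyond the scatter) on this small change, so the trend on the aromatic nitrogen does not end at sec-butyl. Across the series, 1-methylbutyl in place of methyl gives a 100-fold lower number from compound 1 to compound 3 (2.00 log units; beyond the scatter) in the same direction as the earlier step. No measured evidence on hand accounts for these steps.

On these data alone, whether a longer chain such as 1-methylpentyl continues this trend remains open. So does the effect of a cyclopentyl ring on the same nitrogen.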